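A few compounds are considered here, and "the series" means these few. Any claim that something is new, unique, unknown or untested is made for them only; others in the source may bear on it.

Three compounds have been measured in an assay for binding affinity to Apoptosis regulator Bcl-2 (Homo sapiens), read by fluorescence polarization, with stated times of 30 min and 20 min; on this read-out lower numbers stand for stronger inhibition and higher numbers for weaker inhibition:

Compound 1 `O=C(NCCNS(=O)(=O)c1sccc1-c1ccccc1Oc1ccc(O)c(O)c1)Nc1cc(Cl)cc(Cl)c1` gives 4600 nM.
Compound 2 `O=C(NCCNS(=O)(=O)c1ccc(-c2ccccc2Oc2ccc(O)c(O)c2)s1)Nc1cc(Cl)cc(Cl)c1` gives 3600 nM.
Compound 3 `O=C(NCCNS(=O)(=O)c1cc(-c2ccccc2Oc2ccc(O)c(O)c2)cs1)Nc1cc(C(F)(F)F)cc(C(F)(F)F)c1` gives 5200 nM.

Within this small set, compound 1 holds the second highest number, but all three values sit close together: the gap to compound 3 and the gap to compound 2 both lie within the usual scatter of repeated runs, so none of the three can be called more or less potent than another on these numbers.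

Compound 4 `Cc1ccc(-c2ccsc2S(=O)(=O)NCCNC(=O)Nc2cc(Cl)cc(Cl)c2)c(Oc2ccc(O)c(O)c2)c1` differs from compound 1 in one place: methyl in place of hydrogen on an aromatic carbon. Among the measured compounds shown here, no measured pair in the set shows a change of this kind, so the size of its effect in this assay is not known from the data. A single added methyl on an aromatic carbon is among the smallest changes possible, and without a shown step there is no reason to expect movement beyond the scatter in either direction. The estimate for compound 4 is therefore 4200 nM, with a plausible range from 1500 nM to 12000 nM, which means an expected step of a 1.1-fold lower number from compound 1 to compound 4 (0.04 log units; within the scatter) that stays within the scatter.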

Compound 4, inhibition constant: 2900 nM
For compound 4 the middle estimate is 1.4-fold (0.16 log units) above the measured one; low and high end bracket the measured number.
By their numbers in this assay, from the lowest: compounds 4, 2, 1 and 3 (each within the scatter of the next).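

Among the compounds shown here, this is the first step in the set where only one place differs: in this assay, methyl in place of hydrogen gives a 1.6-fold lower number from compound 1 to compound 4 (0.20 log units; within the scatter). The position lies on the six-membered aromatic ring of carbon only, meta to the 3,4-dihydroxyphenoxy group and para to a large group, and with one added carbon here, compound 4 cannot be told apart from compound 1. No independent measurement speaks to what lies behind this result.

From the compounds shown here alone, what remains open is whether a different group at this position, such as an ethyl, a methoxy, a chlorine, an amine or a carboxylic acid, would move the number beyond the scatter. The compounds shown also leave open whether methyl at any other carbon of this ring would give a similar result.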